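Sulfoxide to Sulfone on a Triazole Core in Mice

The source may report more compounds than this note shows. Statements on the series, on what has been measured and on what is new or still open speak of the compounds shown alone.

The read-out throughout is a functional assay on the whole organism for antagonist activity, with Mus musculus as the target; on this read-out lower numbers stand for an effect already at smaller amounts and higher numbers for an effect only at larger amounts of compound. Compound 1 `Cn1c(-c2cccs2)nnc1[S+](C)[O-]` carries a thiophene on the shared core; in this assay compound 1 reaches only the limit of > 200 mg/kg. Compound 2 `Cn1c(-c2cccs2)nnc1S(C)(=O)=O` differs by a group of 4 heavy atoms (1 carbon, 2 oxygen, 1 sulfur; no ring) in place of a group of 3 heavy atoms (1 carbon, 1 oxygen, 1 sulfur; no ring), on an aromatic carbon; compound 2 likewise stops at the limit of > 200 mg/kg. The step that the two limits leave unreadable from compound 1 to compound 2 therefore cannot be read, since both values sit at the limit of > 200 mg/kg in this assay, at which 2 of the 3 values shown sit. Among the compounds with values here, compound 3 `Cn1c(-c2ccccc2F)nnc1[S+](C)[O-]` is the only one with a number: compound 3 gives 57.9 mg/kg. How the core of compound 3 differs from that of compound 1 is not broken down here.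

Compound 4 `Cn1c(-c2ccccc2F)nnc1S(C)(=O)=O` is not yet measured. Its change from compound 3 is a group of 4 heavy atoms (1 carbon, 2 oxygen, 1 sulfur; no ring) in place of a group of 3 heavy atoms (1 carbon, 1 oxygen, 1 sulfur; no ring), on an aromatic carbon, the same kind of change as from compound 1 to compound 2, on the same kind of position of the shared core. The step from compound 3 to compound 4 is expected to be about a 1.6-fold higher number from compound 3 to compound 4 (0.19 log units; within the scatter), which rests on compound 3 at 57.9 mg/kg and on the unreadable step that the two limits leave unreadable from compound 1 to compound 2. Compound 4 is expected at roughly 90 mg/kg, somewhere between 35 mg/kg and 200 mg/kg.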

Compound 4, dose for half-maximal effect: > 100 mg/kg
Compound 4: a limit, no number; the forecaster's own chance of this, stated with the estimate: 35%; middle value at least 1.1-fold (0.04 log units) from the limit.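

On the core of compound 3, methylsulfonyl in place of the smaller sulfur-bearing group gives, in this assay, an at least 1.7-fold higher number from compound 3 to compound 4 (0.23 log units; that floor lies within the scatter). That step ends on a limit for compound 4 rather than a number, so it shows only a floor that lies within the scatter and does not show how large the true step is, or that the change raises the number by a real margin. The same change on the core of compound 1 cannot be read, and the two cores therefore cannot be compared, so nothing here shows that the change carries over from one core to the other, because both compounds on that core sit at a limit: the limit of > 200 mg/kg in this assay, at which 2 of the 4 values shown sit.

The compounds shown leave open whether a number could be obtained for this change on any core. Also open, going by these compounds, is what an amine or a carboxylic acid would give in place of methylsulfonyl, at the same place between two ring nitrogen atoms.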